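Series notes: removing the benzyl from compound 2

This account rests on a few compounds, and the source may have more. Where it says the series, first, only, none or still open, it means among the compounds named here.

Measured so far:
compound 1, `CC(=O)OCCOCN1c2ccccc2C(=O)NS1(=O)=O`: > 200 ug/mL, a limit of the test
compound 2, `O=C1c2ccccc2N(COCCO)S(=O)(=O)N1Cc1ccccc1`: 89 ug/mL

Among the compounds with values here, compound 2 holds the only numerical reading in a functional assay on CCRF-CEM cells (Homo sapiens) for cytotoxicity (on this read-out higher numbers stand for lower toxicity in this test and lower numbers for higher toxicity in this test), giving 89 ug/mL. Compound 1 reaches only the limit of that test, > 200 ug/mL. Compound 3, `O=C1NS(=O)(=O)N(COCCO)c2ccccc21`, differs from compound 2 by hydrogen in place of benzyl on an amide-type nitrogen in a ring. Within the data shown here, no measured step covers this change. Compound 1 also carries hydrogen on that nitrogen and sits at the limit of > 200 ug/mL in this assay, at which 1 of the 2 values shown sits, so a move toward lower toxicity seems more likely than no change. Compound 3 is therefore expected near 180 ug/mL, between 70 ug/mL and 300 ug/mL, an estimated step of a 2.0-fold higher number from compound 2 to compound 3 (0.31 log units; beyond the scatter), possibly ending as a limit again.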

Compound 3, half-maximal cytotoxic concentration: 15 ug/mL
Estimate against measurement, compound 3: 12-fold (1.08 log units) above; the whole stated range lies above it.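

In this assay, hydrogen in place of benzyl on the amide-type nitrogen gives a 5.9-fold lower number from compound 2 to compound 3 (0.77 log units; beyond the scatter) and so goes with higher toxicity at this position, not lower. The oxygen end of the chain also counts: an at least 13-fold lower number from compound 1 to compound 3 (1.12 log units; beyond the scatter) follows hydrogen in place of acetyl, with hydrogen on the amide-type nitrogen in both compounds. The reading of compound 1 is a limit: the limit of > 200 ug/mL in this assay, at which 1 of the 3 values shown sits.

Open, going by these compounds, is whether methyl or a longer alkyl chain on that nitrogen reads closer to compound 2 or compound 3. Open too, on these data alone, is whether a longer acyl chain on the oxygen reads like the acetyl of compound 1.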